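Cyanoaziridine ureas: a methyl added on the urea nitrogen

The source may report more compounds than this note shows. Statements on the series, on what has been measured and on what is new or still open speak of the compounds shown alone.

The series consists of three measured cyanoaziridine ureas and one that awaits measurement. In a functional assay on L1210 cells (Mus musculus) for inhibition, read by MTT assay (on this read-out higher numbers stand for weaker inhibition and lower numbers for stronger inhibition), compound 1 `N#CC1CN1C(=O)Nc1ccc(Cl)cc1Cl` gives 33000 nM, compound 2 `N#CC1CN1C(=O)Nc1cccnc1` gives 16000 nM, and compound 3 `CNC(=O)N1CC1C#N` gives 21000 nM. On this small set compound 3 holds a number close to both of the others: the gap to compound 2 and the gap to compound 1 each stay within the usual scatter of repeated measurements, so the three compounds cannot be told apart in this assay on the present numbers.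

Compound 4 `CCNC(=O)N1CC1C#N` differs from compound 3 in one place only: methyl in place of hydrogen on a saturated chain carbon bound to an amide-type nitrogen. Put another way, the change reads methyl to ethyl, or methylamino to ethylamino, on the urea side chain.

Among the compounds with values here, no measured pair in this assay differs by a single change of this kind, so there is no direct precedent for the size of the step. Given that compound 3 sits at 21000 nM and that the three measured compounds show no separation beyond the scatter, the step of a 1.1-fold lower number from compound 3 to compound 4 (0.02 log units; within the scatter) is expected to be small, with no clear direction beyond the scatter. Compound 4 is therefore estimated at 20000 nM, with a range from 8000 nM to 50000 nM.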

Compound 4, half-maximal inhibitory concentration: 14000 nM
Compound 4: middle estimate off by 1.4-fold (0.15 log units), on the high side, within the range that was stated.
By their numbers in this assay, from the lowest: compounds 4, 2, 3 and 1 (each within the scatter of the next, the first and the last beyond it).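

Within the data shown here, the step of a 1.5-fold lower number from compound 3 to compound 4 (0.18 log units; within the scatter) in this assay is the first reading of a single change, since none of the earlier compounds differed from one another in one place only. It shows that methyl in place of hydrogen on a saturated chain carbon bound to an amide-type nitrogen, which turns the methylamino side chain into ethylamino, leaves the number inside what repeated measurements would give, so this extension by one carbon cannot be told from no change at all in this assay. Nothing at hand explains how the side chain acts on these cells, and no outside measurement bears on the result.

On these data alone, whether a longer chain such as propyl or butyl, a branched chain such as isopropyl, or a chain ending in an amine or a carboxylic acid at this place would move the number beyond the scatter remains open. A single pair also cannot say whether the same change would read alike on the side chains of compound 1 or compound 2.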